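A few compounds are considered here, and "the series" means these few. Any claim that something is new, unique, unknown or untested is made for them only; others in the source may bear on it.

The shared core of this small set appears in compound 1 `O=C(Nc1cc(C(F)(F)F)ccc1N1CCCC1)c1cccnc1Cl` and in compound 2 `O=C(Nc1cc(C(F)(F)F)ccc1NC1CCCCC1)c1cccnc1`. In a functional assay on NALM-6 cells (Homo sapiens) for cytotoxicity, read by MTT assay, with a stated time of 48 h (a higher number here means a weaker inhibitor, a lower number a stronger inhibitor), compound 2 gives 52300 nM. In this assay compound 1 gives "not active" (no number reported), so no single number is attached to it. For the measured compounds named here, compound 2 therefore stands as the only compound with a measured value. Compound 3 `O=C(Nc1cc(C(F)(F)F)ccc1N1CCCC1)c1cccnc1` has not yet been measured. It differs from compound 2 in one place: pyrrolidin-1-yl in place of cyclohexylamino on an aromatic carbon. Going by the values given here, no step between two measured compounds is available to show how large such a change can be. Compound 1, which carries the same pyrrolidin-1-yl group, gave "not active" (no number reported) in this assay, so compound 3 is expected to lean toward a weaker inhibitor, if a number is obtained at all. The step from compound 2 to compound 3 is estimated as a 1.4-fold higher number from compound 2 to compound 3 (0.16 log units; within the scatter). Compound 3 is estimated at 75000 nM in this assay, within a range of 25000 nM to 250000 nM.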

Compound 3, half-maximal inhibitory concentration: "not active" (no number reported)
The entry for compound 3 holds no number, and the estimate cannot be compared.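

Like compound 1, compound 3 gives "not active" (no number reported) in this assay and so no step from compound 2 to compound 3 can be read. The compounds shown leave open how far pyrrolidin-1-yl in place of cyclohexylamino shifts the value, and nothing measured here bears on this result.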